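Swapping a Branched Amine for a Bromobenzyl Group

A few compounds are considered here, and "the series" means these few. Any claim that something is new, unique, unknown or untested is made for them only; others in the source may bear on it.

Going by the values given here, compound 1 `CN(C)CCN(CCN(C)C)c1cccc(C(=O)N2CCc3ccc(OS(N)(=O)=O)cc3C2)c1` gives 0% in an assay on HEK293 cells for inhibition of Steryl-sulfatase (Homo sapiens), tested at 0.1 uM (a lower number here means a weaker effect, a higher number a stronger effect of the compound at the concentration tested), the lowest of the three numbers known so far. Compound 2 `CN(C)CCN(CCN(C)C)c1ccc(C(=O)N2CCc3ccc(OS(N)(=O)=O)cc3C2)cc1` gives 3.8%, within the scatter of compound 1, while compound 3 `CCCN(CCC)c1ccc(C(=O)N2CCc3ccc(OS(N)(=O)=O)cc3C2)cc1` gives 36.6%, well beyond it. Compound 4 `CCN(Cc1cccc(Br)c1)c1cccc(C(=O)N2CCc3ccc(OS(N)(=O)=O)cc3C2)c1` differs from compound 1 in one place: (3-bromobenzyl)(ethyl)amino in place of bis(2-(dimethylamino)ethyl)amino on an aromatic carbon. The measured step that bears on this change is the one in which the same group leaves in favour of dipropylamino. Because a number 32.8 percentage points higher from compound 2 to compound 3 (beyond the scatter) was a large rise, a rise beyond the scatter is also expected for compound 4 in this assay, although the entering group here is a different one and sits meta to a large group, so its size is uncertain. The estimate for compound 4 is 30%, with a range from 8% to 55%. This corresponds to an expected step of a number 30 percentage points higher from compound 1 to compound 4 (beyond the scatter).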

Compound 4, a percentage reported as inhibition, at one concentration (the size of the read-out at that concentration, not a potency): 20.9%
Compound 4: middle estimate off by 9.1 percentage points, on the high side, within the range that was stated.
By their numbers in this assay, from the lowest: compounds 1 and 2 (each within the scatter of the next); then compound 4; then compound 3.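

At this place, meta to a large group, the bis(2-(dimethylamino)ethyl)amino group of compound 1 can be exchanged with a gain in this assay: the step is a number 20.9 percentage points higher from compound 1 to compound 4 (beyond the scatter). Both groups hold 11 heavy atoms, so the gain comes with no change in that count, only with a different make-up of the group.

As far as these compounds go, whether the aromatic ring, the bromine or the loss of the dimethylamino nitrogens matters stays open, and a plain benzyl group in place of the 3-bromobenzyl group would help to separate these. No measurement shown here accounts for the gain.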